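Indole sulfonamides at the serotonin-6 receptor: methoxy to piperidinyl

The source may hold more compounds than are shown below. What is called first, only, known or untested is meant among the compounds shown, and "the series" means these compounds.

Measured compounds:
compound 1, `COc1ccc2c(ccn2S(=O)(=O)c2ccccc2)c1`, 127 nM
compound 2, `CCCCS(=O)(=O)n1ccc2c(N(C)C)cccc21`, 49900 nM

In an assay on isolated protein for displacement of a labelled ligand from 5-hydroxytryptamine receptor 6 (Homo sapiens), read by scintillation counting, with a stated time of 1 h (on this read-out lower numbers stand for stronger inhibition and higher numbers for weaker inhibition), compound 1 gives 127 nM, the lowest of the two numbers; compound 2 gives 49900 nM, a far higher number, and the two structures differ in more than one place, so only the two values themselves can be compared. Compound 3, `O=S(=O)(c1ccccc1)n1ccc2cc(N3CCCCC3)ccc21`, is not yet measured in this assay. It differs from compound 1 by piperidin-1-yl in place of methoxy on an aromatic carbon. Going by the values given here, no single-change step is known in this set, so the size of the change is uncertain; a small step, likely within the scatter or a modest lowering, is expected, a 2.1-fold lower number from compound 1 to compound 3 (0.33 log units; beyond the scatter). Compound 3 is estimated at 60 nM, with a range from 15 nM to 250 nM.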

Compound 3, inhibition constant: 360 nM
Estimate against measurement, compound 3: 6.0-fold (0.78 log units) below; measured number above the stated range.
By their numbers in this assay, from the lowest: compound 1; then compound 3; then compound 2.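

In this assay, going by these compounds alone, the first single-change step is a 2.8-fold higher number from compound 1 to compound 3 (0.45 log units; beyond the scatter) for piperidin-1-yl in place of methoxy on this aromatic carbon. The position therefore accepts a six-membered non-aromatic ring with only a modest penalty, which the two earlier compounds could not show. Nothing measured here accounts for the step.

Open, as far as these compounds go, is whether a piperazine or morpholine ring on the same carbon would give a number nearer that of compound 1, or a lower one. Also open, from the compounds shown here alone, is how a small amine such as dimethylamino would behave there.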